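Extending the amide side chain of compound 2

A few compounds are considered here, and "the series" means these few. Any claim that something is new, unique, unknown or untested is made for them only; others in the source may bear on it.

In an ADME assay on the whole organism (strain CD1) for pharmacokinetics, with Mus musculus as the target, read by LC-MS, at a dose of 5 mg/kg by the oral route (on this read-out higher numbers stand for higher exposure at the dose given and lower numbers for lower exposure), compound 1 `Cc1c(Oc2cnc(C(=O)NCCO)cn2)ccc2c1B(O)OC2` gives 29600 ng.h/mL and compound 2 `Cc1c(Oc2cnc(C(=O)NC(C)CO)cn2)ccc2c1B(O)OC2` gives 33000 ng.h/mL. Within the data shown here, compound 2 therefore stands level with the only other measured compound, the step between them being a 1.1-fold higher number from compound 1 to compound 2 (0.05 log units; within the scatter). Compound 3 `CCC[C@H](CO)NC(=O)c1cnc(Oc2ccc3c(c2C)B(O)OC3)cn1` departs from compound 2 in one place: 1-(hydroxymethyl)butyl in place of 1-(hydroxymethyl)ethyl on an amide-type nitrogen. Among the measured compounds shown here, only one measured step bears on this change, the methyl in place of hydrogen on a saturated chain carbon that links compound 1 to compound 2, and its size is a 1.1-fold higher number from compound 1 to compound 2 (0.05 log units; within the scatter). That single small step is thin support for a longer chain, so the range is kept wide. No shift beyond the scatter is expected, and the estimated step is a 1.3-fold lower number from compound 2 to compound 3 (0.10 log units; within the scatter). The estimate for compound 3 is 26000 ng.h/mL, with an expected range of 10000 ng.h/mL to 60000 ng.h/mL.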

Compound 3, area under the concentration-time curve: 21600 ng.h/mL
The estimate for compound 3 lay 1.2-fold (0.08 log units) above the measured number, within the range that was stated.
By their numbers in this assay, from the lowest: compounds 3, 1 and 2 (each within the scatter of the next).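

In this assay, 1-(hydroxymethyl)butyl in place of 1-(hydroxymethyl)ethyl on the amide-type nitrogen gives a 1.5-fold lower number from compound 2 to compound 3 (0.18 log units; within the scatter) and propyl in place of hydrogen on the saturated chain carbon gives a 1.4-fold lower number from compound 1 to compound 3 (0.14 log units; within the scatter) so neither change moves the number beyond the scatter. Across hydrogen, methyl and now propyl on that carbon, the three compounds therefore stand level, and the position accepts a chain as long as the one in compound 3 without a measurable shift in exposure. No measurement shown offers an explanation for this flat result.

Going by these compounds, whether a longer chain, a phenyl ring, an amine or a carboxylic acid on that carbon would shift exposure beyond the scatter remains open. So does the outcome for the opposite stereocentre of the 1-(hydroxymethyl)butyl group.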